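Methyl for fluoro on the aryl ketone of compound 2

The source may report more compounds than this note shows. Statements on the series, on what has been measured and on what is new or still open speak of the compounds shown alone.

Compound 1, `O=C(/C=C/c1ccc2c(c1)B(O)OC2)c1ccc(I)cc1`: > 100000 nM
Compound 2, `O=C(/C=C/c1ccc2c(c1)B(O)OC2)c1cccc(F)c1`: 26700 nM

In a toxicity assay on WI-38 cells (Homo sapiens) for cytotoxicity, read by MTT assay, with a stated time of 48 h (on this read-out higher numbers stand for weaker inhibition and lower numbers for stronger inhibition), compound 2 gives 26700 nM and holds the only number shown. The value of compound 1 is a limit of the assay (the limit of > 100000 nM in this assay, at which 1 of the 2 values shown sits). Compound 3 `Cc1cccc(C(=O)/C=C/c2ccc3c(c2)B(O)OC3)c1` is compound 2 with methyl in place of fluoro on an aromatic carbon. Among the measured compounds shown here, the one measured step, an at least 3.7-fold lower number from compound 1 to compound 2 (0.57 log units; beyond the scatter), exchanged the whole aryl group on the carbonyl carbon and bears on this smaller change only loosely. For the measured compounds named here, no step within the scatter is expected from compound 2 to compound 3, so the estimate is a 1.2-fold higher number from compound 2 to compound 3 (0.08 log units; within the scatter). Compound 3 is thus estimated at 32000 nM in this assay, between 11000 nM and 100000 nM.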

Compound 3, half-maximal inhibitory concentration: 16700 nM
The estimate for compound 3 lay 1.9-fold (0.28 log units) above the measured number; the measured number falls inside the stated range.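

In this assay, methyl in place of fluoro, meta to a large group, gives a 1.6-fold lower number from compound 2 to compound 3 (0.20 log units; within the scatter), so the two groups cannot be told apart at this place. The 3-methylphenyl group also gives an at least 5.9-fold lower number from compound 1 to compound 3 (0.77 log units; beyond the scatter), so the separation from 4-iodophenyl seen with 3-fluorophenyl is not tied to fluoro alone. The value of compound 1 is a limit of the assay: the limit of > 100000 nM in this assay, at which 1 of the 3 values shown sits.

On these data alone, whether an amine or a carboxylic acid at this place would move the number beyond the scatter stays open. The steps from compound 1 change group and place together, and the compounds shown do not separate the two.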